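A few compounds are considered here, and "the series" means these few. Any claim that something is new, unique, unknown or untested is made for them only; others in the source may bear on it.

Compound 1, `CCOC(=O)c1sc2cccc(C)c2c1Nc1cc(OC)c(OC)c(OC)c1`, in a functional assay on Jurkat cells (Homo sapiens) for cytotoxicity, read by MTT assay, with a stated time of 72 h; a higher number here means a weaker inhibitor, a lower number a stronger inhibitor: 5670 nM
Compound 2, `CCOC(=O)c1sc2c(OC)c(C)c(C)c(C)c2c1Nc1cc(OC)c(OC)c(OC)c1`, in this assay: 56.5 nM

Compound 1 gives the highest of the two numbers; its nearest neighbour, compound 2, gives a far lower one, a gap beyond the scatter. Compound 3, `CCOC(=O)c1sc2ccccc2c1Nc1cc(OC)c(OC)c(OC)c1`, is not yet measured. It differs from compound 1 thus: hydrogen in place of methyl on an aromatic carbon. For the measured compounds named here, no pair of measured compounds isolates this change, so the expectation rests on compound 1 alone. The expected step, a 1.2-fold higher number from compound 1 to compound 3 (0.09 log units; within the scatter), is small, toward a weaker inhibitor if anything, and not beyond the scatter. Compound 3 is therefore estimated at 7000 nM, within a range from 2000 nM to 25000 nM.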

Compound 3, half-maximal inhibitory concentration: 3020 nM
Beside the measured number, compound 3's estimate is 2.3-fold (0.37 log units) above it, and the stated range covers the measured number.
By their numbers in this assay, from the lowest: compound 2; then compounds 3 and 1 (each within the scatter of the next).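

With hydrogen in place of methyl on this aromatic carbon, the step in this assay is a 1.9-fold lower number from compound 1 to compound 3 (0.27 log units; within the scatter). For the compounds shown here, for the first time, this isolates the methyl at this position, and on its own it makes no difference beyond the scatter. Nothing at hand explains this result. As far as these compounds go, whether a chlorine atom, an amine or an ethyl chain on this carbon would move the number stays open. Compound 2 differs from compound 1 in more than one place, so its number cannot be assigned to any single group.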